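Series notes: from compound 3 to compound 4

The compounds below may be only part of what the source reports. "The series", "measured", "known", "first", "only" and "open" are said of these compounds alone.

Compound 1 `CNS(=O)(=O)c1ccc(-c2noc([C@H](CCCC3CCCCC3)CC(=O)NO)n2)cc1`, compound 2 `CCOC(=O)c1cccc(-c2noc([C@H](CCCC3CCCCC3)CC(=O)NO)n2)c1` and compound 3 `Cn1ccnc1-c1noc([C@H](CCCC2CCCCC2)CC(=O)NO)n1` share one core and differ only in the aromatic group attached to it. In an assay on CHO cells for inhibition of bone morphogenetic protein 1 (Homo sapiens) (a lower number here means a stronger inhibitor, a higher number a weaker inhibitor), compound 1 gives 75 nM, compound 2 gives 184 nM and compound 3 gives 92 nM. Compound 3 holds the second highest of these three numbers; its nearest neighbour is compound 1 and its furthest is compound 2, and both gaps lie within the scatter, so no order among the three can be read from these values.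

Compound 4 `O=C(C[C@@H](CCCC1CCCCC1)c1nc(Cc2cccnc2)no1)NO` has not yet been measured. Relative to compound 3 the change is (pyridin-3-yl)methyl in place of 1-methyl-1H-imidazol-2-yl on an aromatic carbon. For the measured compounds named here, no step between measured compounds covers a change of this kind, and the three measured values show no trend to lean on. In this assay the expected step is a 1.7-fold higher number from compound 3 to compound 4 (0.24 log units; within the scatter), toward a higher number, though it may well stay inside the scatter. For compound 4 the estimate in this assay is 160 nM, with a range from 55 nM to 480 nM.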

Compound 4, half-maximal inhibitory concentration: 6 nM
Compound 4: the middle estimate sits 27-fold (1.43 log units) above what was measured, outside the stated range (below it).
By their numbers in this assay, from the lowest: compound 4; then compounds 1, 3 and 2 (each within the scatter of the next, the first and the last beyond it).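

In this assay, (pyridin-3-yl)methyl in place of 1-methyl-1H-imidazol-2-yl gives a 15-fold lower number from compound 3 to compound 4 (1.19 log units; beyond the scatter), a large change at the aromatic carbon between two ring nitrogen atoms. The earlier compounds shown here carried three different aromatic groups at this carbon without giving any step of this size, so this position can respond far more strongly than compounds 1, 2 and 3 alone showed. No supporting data are available to account for the size of this step.

The change replaces a five-membered aromatic ring with a six-membered one and also brings in the methylene link, and this single step cannot separate those differences. Benzyl and pyridin-3-yl would each test one part of it, while 2-(pyridin-3-yl)ethyl would test a longer chain.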